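The source may report more compounds than this note shows. Statements on the series, on what has been measured and on what is new or still open speak of the compounds shown alone.

In an in vivo ADME assay on the whole organism (strain Sprague-Dawley) for metabolic stability, with Rattus norvegicus as the target (a lower number here means that the compound disappears faster, a higher number that the compound lasts longer), the three measured compounds stand as follows:
- compound 1 `CCCCCOC(=O)N1CCN(C(=O)[C@H](CCC(=O)O)NC(=O)c2cc(N3CCC(C(=O)N(CC)CC)CC3)nc(-c3ccccc3)n2)CC1` gives 0.00667 h
- compound 2 `CCCCCOC(=O)N1CCN(C(=O)[C@H](CCC(=O)O)NC(=O)c2cc(N3CCC(OCCO)CC3)nc(-c3ccccc3)n2)CC1` gives 0.00833 h
- compound 3 `CCCCCOC(=O)N1CCN(C(=O)[C@H](CCC(=O)O)NC(=O)c2cc(N3CCC(CNC)CC3)nc(-c3ccccc3)n2)CC1` gives 0.0117 h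

Compound 3 has the highest of the three numbers, but its neighbours lie close: a 1.4-fold higher number from compound 2 to compound 3 (0.15 log units; within the scatter) and a 1.8-fold higher number from compound 1 to compound 3 (0.24 log units; within the scatter), both within the scatter, so the three compounds cannot be told apart on these data. Compound 4 `CCCCCOC(=O)N1CCN(C(=O)[C@H](CCC(=O)O)NC(=O)c2cc(N3CCC(C(N)=O)CC3)nc(-c3ccccc3)n2)CC1` is the next step from compound 3. The change is carbamoyl in place of (methylamino)methyl on a saturated ring carbon; read one bond further out, it is 4-((methylamino)methyl)piperidin-1-yl to 4-carbamoylpiperidin-1-yl.

The measured steps that bear on this are the ones at the same saturated ring carbon: a 1.8-fold higher number from compound 1 to compound 3 (0.24 log units; within the scatter) and a 1.4-fold higher number from compound 2 to compound 3 (0.15 log units; within the scatter). Both swapped one group for another at this place, and neither moved the number beyond the scatter. Compound 1 already carries a carbamoyl-type group there, diethylcarbamoyl, and its value sits close to the others. The expectation for compound 4 is therefore no step beyond the scatter, as in a 1.3-fold lower number from compound 3 to compound 4 (0.11 log units; within the scatter). On that basis compound 4 is estimated at 0.009 h, with a range from 0.004 h to 0.02 h.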

Compound 4, half-life: 0.00667 h
Compound 4: the middle estimate sits 1.3-fold (0.13 log units) above what was measured; measured number inside the range.
By their numbers in this assay, from the lowest: compounds 1, 4, 2 and 3 (each within the scatter of the next).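

In this assay the carbamoyl group of compound 4 adds a fourth group on this saturated ring carbon, and the steps of a 1.8-fold lower number from compound 3 to compound 4 (0.24 log units; within the scatter) and a 1.2-fold lower number from compound 2 to compound 4 (0.10 log units; within the scatter) both stay within the scatter, so all four compounds remain impossible to tell apart. Going by these compounds alone, the new pair also isolates a change that the earlier compounds did not: with amino in place of diethylamino on the carbonyl carbon, the step reads no change at the digits printed from compound 1 to compound 4 (within the scatter) and is likewise within the scatter, so removing the two ethyl groups from this amide leaves no readable mark on the half-life.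

From the compounds shown here alone, whether a carboxylic acid or a phenyl ring on this same ring carbon would give a step beyond the scatter remains open. The shared core is also identical in all four compounds, so its part in setting these short half-lives cannot be read from this set. No measurement here offers an explanation for the small size of these steps.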